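Swapping a fluorophenyl for a chlorophenyl: expected clearance

The source may hold more compounds than are shown below. What is called first, only, known or untested is meant among the compounds shown, and "the series" means these compounds.

Measured compounds:
compound 1 `O=S(=O)(c1cccc(F)c1)c1cnc2c(F)cccc2c1-c1ccc(Cl)cc1`: 0.62 mL/min
compound 2 `O=S(=O)(c1cccc(F)c1)c1cnc2c(F)cccc2c1-c1cccc(F)c1`: 1.14 mL/min
compound 3 `O=S(=O)(c1cc(F)cc(F)c1)c1cnc2c(F)cccc2c1-c1cccc(F)c1`: 1.18 mL/min

These three values all come from an ADME assay on microsomes from liver (Homo sapiens) for metabolic stability, tested at 2.5 uM; on this read-out higher numbers stand for fast clearance and lower numbers for slow clearance. Compound 4 `O=S(=O)(c1cc(F)cc(F)c1)c1cnc2c(F)cccc2c1-c1ccc(Cl)cc1` has not yet been tested. It differs from compound 3 by 4-chlorophenyl in place of 3-fluorophenyl on an aromatic carbon. The same change has already been made once between measured compounds: compound 1 differs from compound 2 by 4-chlorophenyl in place of 3-fluorophenyl on an aromatic carbon, and this gave a 1.8-fold lower number from compound 2 to compound 1 (0.26 log units; within the scatter). The two cores on which the change is made are not identical; compound 3 differs from compound 2 by fluoro in place of hydrogen on an aromatic carbon, which gave a 1.0-fold higher number from compound 2 to compound 3 (0.01 log units; within the scatter). Since the place of the chlorophenyl swap reads the same word for word in both cases, and the two cores sit at essentially the same clearance, the earlier step is the natural guide.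

The step from compound 3 to compound 4 is expected to be a 1.8-fold lower number from compound 3 to compound 4 (0.26 log units; within the scatter), matching the earlier step, because the identical change produced a 1.8-fold lower number from compound 2 to compound 1 (0.26 log units; within the scatter). Compound 4 is therefore estimated at 0.65 mL/min, with a likely range from 0.35 mL/min to 1.2 mL/min, noting that the earlier step itself lay within the usual scatter.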

Compound 4, intrinsic clearance in a liver preparation (reported as CLH), per the amount of preparation that the assay uses: 0.73 mL/min
The estimate for compound 4 lay 1.1-fold (0.05 log units) below the measured number; measured number inside the range.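

In this assay, the swap of 3-fluorophenyl for 4-chlorophenyl gave a 1.6-fold lower number from compound 3 to compound 4 (0.21 log units; within the scatter), and it read much the same on both cores: the same change on two cores in this assay, a 1.8-fold lower number (0.26 log units; within the scatter) from compound 2 to compound 1 and a 1.6-fold lower number (0.21 log units; within the scatter) from compound 3 to compound 4, 1.1-fold (0.06 log units) apart, within the scatter of two such steps. Fluoro in place of hydrogen gave a 1.2-fold higher number from compound 1 to compound 4 (0.07 log units; within the scatter), and this change also matched its earlier counterpart: the same change on two cores in this assay, a 1.0-fold higher number (0.01 log units; within the scatter) from compound 2 to compound 3 and a 1.2-fold higher number (0.07 log units; within the scatter) from compound 1 to compound 4, 1.1-fold (0.06 log units) apart, within the scatter of two such steps. Every one of these steps lies within the usual scatter, so the agreement shows that neither change behaved differently on these two closely related cores, but it does not show that either change truly shifts clearance, or that the same would hold on a core that differs by more than one fluoro.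

The swap alters both the atom and its place on the phenyl ring, and these compounds cannot separate the two. From the compounds shown here alone, it also remains open how clearance would respond to an amine, a carboxylic acid or a longer chain in place of the 4-chlorophenyl.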